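The compounds below may be only part of what the source reports. "The series", "measured", "known", "first", "only" and "open" are said of these compounds alone.

Three compounds have been measured so far in an ADME assay on microsomes from liver (Mus musculus) for metabolic stability, read by LC-MS, with a stated time of 10 min (on this read-out higher numbers stand for a more stable compound and lower numbers for a less stable compound), with these results:

- Compound 1 `CN(C[C@H]1Cc2c(cccc2N2CCNC(C)(C)C2)CN1)[C@H]1CCCc2cccnc21` gives 44%
- Compound 2 `FC1(F)CCC(CN(C[C@H]2Cc3c(cccc3N3CCNCC3)CN2)[C@H]2CCCc3cccnc32)CC1` gives 76.6%
- Compound 3 `CC(C)N(C[C@H]1Cc2c(cccc2N2CCNCC2)CN1)[C@H]1CCCc2cccnc21` gives 91%

Compound 1 has the lowest number of the three, and its gaps to compound 2 and compound 3 both lie beyond the scatter. Compound 4 `CN(C[C@H]1Cc2c(cccc2N2C[C@@H]3C[C@H]2CN3)CN1)[C@H]1CCCc2cccnc21` has not been measured yet. The structural change from compound 1 is a group of 7 heavy atoms (5 carbon, 2 nitrogen; 2 five-membered non-aromatic rings with 1 hetero atom each) in place of a group of 8 heavy atoms (6 carbon, 2 nitrogen; one six-membered non-aromatic ring with 2 hetero atoms), on an aromatic carbon and nothing else differs.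

Among the compounds with values here, no measured step covers this swap. Within the data shown here, the only step between two compounds differing in one place, a number 14.4 percentage points higher from compound 2 to compound 3 (beyond the scatter) and modest in size, concerns isopropyl in place of (4,4-difluorocyclohexyl)methyl on an amine nitrogen. It therefore shows only how large a single change can be in this series.

Compound 2 and compound 3 each differ from compound 1 in more than one place, so their higher numbers are only a weak hint. Still, compound 1 at 44% leaves plenty of room upward, and compound 3 reaches 91% on the same scale. A modest rise is the best guess, though a result within the scatter remains quite possible.

The expected step is a number 14 percentage points higher from compound 1 to compound 4 (beyond the scatter) and it is uncertain. For compound 4 the estimated value is 58% within an expected range from 35% to 80% overall.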

Compound 4, percent of the compound remaining: 36.3%
For compound 4 the middle estimate is 21.7 percentage points above the measured one; measured number inside the range.
By their numbers in this assay, from the lowest: compounds 4 and 1 (each within the scatter of the next); then compound 2; then compound 3.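

In this assay, the group with two five-membered non-aromatic rings in place of 3,3-dimethylpiperazin-1-yl gives a number 7.7 percentage points lower from compound 1 to compound 4 (within the scatter). This is the first pair shown that differs only in the group on this aromatic carbon, so it is the first direct reading of this position. Within the data shown here, it shows that this particular swap, which changes the ring pattern and removes one heavy atom, does not separate the two compounds on this read-out, and that this position did not give the clear change seen in the one earlier step, which was made on an amine nitrogen. No measurement at hand bears on why the two groups read alike.

From the compounds shown here alone, whether a different kind of group on this aromatic carbon, such as a morpholine ring or an open-chain amine like dimethylamino, would move the number remains open. Also open is what a group other than methyl on the amine nitrogen would do while either of these two groups stays on the aromatic carbon, as no pair shown isolates that change.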